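The compounds below may be only part of what the source reports. "The series", "measured", "known", "first", "only" and "open" are said of these compounds alone.

Of the compounds shown here, two have numbers so far. Compound 1 `OCCCc1cn(CCNc2nonc2/C(=N/O)Nc2ccc(F)c(Br)c2)nn1` gives 98 nM in an assay on isolated protein for inhibition of Indoleamine 2,3-dioxygenase 1 (Homo sapiens); on this read-out lower numbers stand for stronger inhibition and higher numbers for weaker inhibition. Compound 2 `CC(C)(O)c1cn(CCNc2nonc2/C(=N/O)Nc2ccc(F)c(Br)c2)nn1` gives 115 nM in this assay. Going by the values given here, the one measured step, a 1.2-fold higher number from compound 1 to compound 2 (0.07 log units; within the scatter), puts the two within the scatter of each other, so compound 2 stands level with compound 1 and nothing separates them.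

Compound 3 `CC(C)CC(C)(O)c1cn(CCNc2nonc2/C(=N/O)Nc2ccc(F)c(Br)c2)nn1` is the next member, not yet measured. It differs from compound 2 by isopropyl in place of hydrogen on a saturated chain carbon, two bonds along the chain from an aromatic carbon and an oxygen on a saturated carbon. Among the compounds with values here, the only measured step that bears on this place is a 1.2-fold higher number from compound 1 to compound 2 (0.07 log units; within the scatter), which reworked the same hydroxyalkyl substituent on the aromatic carbon without moving the number beyond the scatter. On that basis the step from compound 2 to compound 3 is expected to stay within the scatter, with no direction to call, and is estimated as a 1.1-fold higher number from compound 2 to compound 3 (0.05 log units; within the scatter). Compound 3 is therefore expected to give about 130 nM in this assay, with a likely range from 50 nM to 350 nM.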

Compound 3, half-maximal inhibitory concentration: 51 nM
The estimate for compound 3 lay 2.5-fold (0.41 log units) above the measured number; measured number inside the range.
By their numbers in this assay, from the lowest: compounds 3, 1 and 2 (each within the scatter of the next, the first and the last beyond it).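

Extending the methyl of 1-hydroxy-1-methylethyl to isobutyl, which gives 1-hydroxy-1,3-dimethylbutyl, is the first change at this substituent to pass the scatter in this assay, with a 2.3-fold lower number from compound 2 to compound 3 (0.35 log units; beyond the scatter). The added isopropyl, of 3 carbons, is therefore tolerated on the saturated chain carbon, and the number responds to it, which the swap of 3-hydroxypropyl for 1-hydroxy-1-methylethyl did not show. Against the 3-hydroxypropyl of compound 1 the picture is weaker, with a 1.9-fold lower number from compound 1 to compound 3 (0.28 log units; within the scatter), so compound 3 separates from compound 2 only and no order can be set between compound 1 and compound 3.

No measurement at hand accounts for this step. Going by these compounds, whether a longer chain, a phenyl ring or an amine at the same carbon would carry the number further remains open, as does whether the hydroxy group is needed there.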